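Hydrogen for chloro on the aromatic ring of compound 1

The compounds below may be only part of what the source reports. "The series", "measured", "known", "first", "only" and "open" are said of these compounds alone.

Measured compounds, with their readings in an ADME assay on HEL cells (Homo sapiens) for cytotoxicity, read by microscopy; on this read-out higher numbers stand for lower toxicity in this test and lower numbers for higher toxicity in this test:
Compound 1 `O=c1ccn(CCCCCOc2ccc(Cl)cc2)c(=O)[nH]1` gives > 100000 nM.
Compound 2 `O=c1ccn(CCCCCCCCOc2ccc(Br)cc2)c(=O)[nH]1` gives >= 100000 nM.
Compound 3 `O=c1ccn(CCCCOc2ccc(Br)cc2)c(=O)[nH]1` gives 100000 nM.

The reading for compound 1 is not a number but a limit of this assay; compound 1 sits at the limit of > 100000 nM in this assay, at which 1 of the 3 values shown sits. Compound 2 likewise stands at a limit, namely (the limit of >= 100000 nM in this assay, at which 1 of the 3 values shown sits). Compound 3 is the only one of the three with a plain number, and that number lies where the two limits begin, so none of the three readings can be told apart from the others. Among the measured compounds shown here, no pair of measured compounds differs in a single place, so compound 1 stands only at a limit, with one further limit beside it among the values shown.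

The unmeasured compound 4 `O=c1ccn(CCCCCOc2ccccc2)c(=O)[nH]1` differs from compound 1 by hydrogen in place of chloro on an aromatic carbon. For this change in this assay no step beyond the scatter is expected in either direction, since every reading so far sits at or beside the same limit. The expected step is a number no higher from compound 1 to compound 4 (the limit leaves the size open). Compound 4 is therefore estimated at 100000 nM, with a range from 50000 nM to 200000 nM, and it is expected that this assay may again report only a limit.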

Compound 4, minimum cytotoxic concentration: > 100000 nM
Compound 4: no number, only a limit (the forecaster's own chance of this, stated with the estimate: 80%); the middle value sits exactly at the limit.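

In this assay compound 4 stands at a limit, as compound 1 does, so no step can be read between the two: the limit of > 100000 nM in this assay, at which 2 of the 4 values shown sit.

The compounds shown leave open at what concentration, if any, compound 1 and compound 4 would show toxicity in this assay and so whether hydrogen in place of chloro makes any difference.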